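Lengthening the side chain from compound 3 to compound 4

This account rests on a few compounds, and the source may have more. Where it says the series, first, only, none or still open, it means among the compounds named here.

Of the compounds shown here, three sharing one core have so far been tested in a functional assay on the whole organism (Tail, strain ICR) with Mus musculus as the target, in the tail flick test, with a stated time of 30 min, at a dose of 25 umol/kg by the oral route; on this read-out lower numbers stand for a weaker effect and higher numbers for a stronger effect at the one dose given. Compound 1 `N=C(N)NCCC[C@H](NC(=O)CN(c1nc(Cl)nc2[nH]cnc12)C1CC1)C(=O)OCc1ccccc1` gives 23.2%, compound 2 `CC(C)[C@H](NC(=O)CN(c1nc(Cl)nc2[nH]cnc12)C1CC1)C(=O)OCc1ccccc1` gives 33.4%, and compound 3 `NC(=O)C[C@H](NC(=O)CN(c1nc(Cl)nc2[nH]cnc12)C1CC1)C(=O)OCc1ccccc1` gives 24.4%. Within this small set compound 3 stands second highest: its nearest neighbour is compound 1, and the gap between them lies within the scatter, while compound 2 sits further away, also within the scatter. Within the data shown here, the only step beyond the scatter is a number 10.2 percentage points higher from compound 1 to compound 2 (beyond the scatter).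

Compound 4 `NC(=O)CC[C@H](NC(=O)CN(c1nc(Cl)nc2[nH]cnc12)C1CC1)C(=O)OCc1ccccc1` differs from compound 3 by carbamoylmethyl in place of carbamoyl on a saturated chain carbon, two bonds along the chain from an amide-type nitrogen and a carbonyl carbon. The measured steps that bear on this are those that also change the side chain on the same carbon: a number 9 percentage points lower from compound 2 to compound 3 (within the scatter) and a number 1.2 percentage points higher from compound 1 to compound 3 (within the scatter). Among the measured compounds shown here, both stayed within the scatter, even though they swapped groups of quite different kinds, whereas the one modest step, from compound 1 to compound 2, involved a larger exchange than the single added carbon here. On that basis the step from compound 3 to compound 4 in this assay is expected to be a number 1.6 percentage points higher from compound 3 to compound 4 (within the scatter), that is, nothing beyond the scatter. Compound 4 is therefore estimated to give 26%, with a range from 15% to 38%.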

Compound 4, a percentage reported as activity, at one dose (the size of the read-out at that dose, not a potency): 30.8%
Compound 4: the middle estimate sits 4.8 percentage points below what was measured; the measured number falls inside the stated range.
By their numbers in this assay, from the lowest: compounds 1, 3, 4 and 2 (each within the scatter of the next, the first and the last beyond it).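

Adding one carbon to the side chain, carbamoylmethyl to 2-carbamoylethyl, moved the result by no more than the usual scatter (a number 6.4 percentage points higher from compound 3 to compound 4 (within the scatter)), so this position accepted the longer amide chain without a change that can be read. Compound 4 also lies within the scatter of both other compounds (a number 2.6 percentage points lower from compound 2 to compound 4 (within the scatter); a number 7.6 percentage points higher from compound 1 to compound 4 (within the scatter)), even though compound 1 and compound 2 are themselves separated by a step beyond it, and so the set does not divide cleanly into two levels at this position. No measurement is at hand that would account for these numbers.

The compounds shown leave open whether a carboxylic acid in place of the terminal carbamoyl, an amine at the end of the chain, or a chain longer than 2-carbamoylethyl would stay within the scatter of these values or move clearly beyond it. From the compounds shown here alone, each number also stands for a single oral dose at a single time, so it remains open whether these side chains would separate at other doses or times.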